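A few compounds are considered here, and "the series" means these few. Any claim that something is new, unique, unknown or untested is made for them only; others in the source may bear on it.

Measured so far:
Compound 1 `Cc1ccc(C(=O)Nc2cccc(NC(=O)COc3ccc4c(=O)ccoc4c3)c2)cc1` — in an assay on isolated protein for inhibition of Rho-associated protein kinase 1 (Homo sapiens), read by scintillation counting, radiometric assay and 33P incorporation, with a stated time of 40 min, in the presence of a further agent that is not named here (a lower number here means a stronger inhibitor, a higher number a weaker inhibitor), compound 1 gives 183 nM.
Compound 2 `Cn1ccc(S(=O)(=O)Nc2cccc(NC(=O)COc3ccc4c(=O)ccoc4c3)c2)n1` — in this assay compound 2 reaches only the limit > 10000 nM, a limit and not a number.

Going by the values given here, compound 1 therefore stands as the only compound with a number in this assay; the one further value is a limit, as the evidence shows (the limit of > 10000 nM in this assay, at which 1 of the 2 values shown sits). Among the compounds with values here, the single measured step, an at least 54-fold higher number from compound 1 to compound 2 (1.73 log units; beyond the scatter), exchanges the whole group on the amide nitrogen for a five-membered aromatic ring with two hetero atoms carried on a sulfonyl, and it gives a large loss.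

Compound 3 `Nc1ccc(C(=O)Nc2cccc(NC(=O)COc3ccc4c(=O)ccoc4c3)c2)cc1` keeps the core of compound 1 and the benzamide, differing only by amino in place of methyl on an aromatic carbon. Within the data shown here, the one measured step does not touch this position and does not bear on a single-atom swap on the six-membered aromatic ring of carbon only; it offers no guide to direction. In this assay, compound 3 is expected to show a step of a 1.1-fold higher number from compound 1 to compound 3 (0.04 log units; within the scatter), that is, a change that is not beyond the scatter. The estimate for compound 3 in this assay is 200 nM, with a range from 60 nM to 700 nM.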

Compound 3, half-maximal inhibitory concentration: 802 nM
Compound 3: the middle estimate sits 4.0-fold (0.60 log units) below what was measured, outside the stated range (above it).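

In this assay, the position para to a large group on the benzamide ring proves sensitive to a single-atom swap: amino in place of methyl gives a 4.4-fold higher number from compound 1 to compound 3 (0.64 log units; beyond the scatter), so the change from 4-methylphenyl to 4-aminophenyl is not neutral, and methyl is the better of the two groups shown here. The amino compound still keeps the six-membered aromatic ring of carbon only on its carbonyl, and against the sulfonyl compound with the five-membered ring the result is an at least 12-fold lower number from compound 2 to compound 3 (1.09 log units; beyond the scatter), so this swap costs far less than replacing the whole group on the nitrogen. Compound 2 is held at a limit and not a number, so that step is a bound only: the limit of > 10000 nM in this assay, at which 1 of the 3 values shown sits.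

As far as these compounds go, with only methyl and amino at this position, no trend can be read, and it stays open whether a hydroxyl, a methoxy, a chlorine or a dimethylamino group would fall nearer compound 1 or compound 3. Nothing shown explains the step, and the effect of the same swap at other places on that ring also stays open.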